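Difluoroethoxy in Place of Trifluoromethyl at the Weaker End

The source may report more compounds than this note shows. Statements on the series, on what has been measured and on what is new or still open speak of the compounds shown alone.

Within the data shown here, compound 2 `N#Cc1cnc(NCc2cncnc2C(F)(F)F)cc1N[C@H]1CC[C@@H](O)CC1` gives 450 nM in an assay on isolated protein for inhibition of protein kinase C theta type (Homo sapiens), read by TR-FRET, with a stated time of 2 h (on this read-out lower numbers stand for stronger inhibition and higher numbers for weaker inhibition), the higher of the two numbers measured so far, whereas compound 1 `N#Cc1cnc(NCc2cnccc2C(F)(F)F)cc1N[C@H]1CC[C@@H](n2cncn2)CC1` gives 100 nM, a gap beyond the usual scatter. Compound 3 `N#Cc1cnc(NCc2cncnc2OCC(F)F)cc1N[C@H]1CC[C@@H](O)CC1` differs from compound 2 by 2,2-difluoroethoxy in place of trifluoromethyl on an aromatic carbon. Among the measured compounds shown here, no measured pair in this set shows such a change, so nothing here tells its direction. Compound 3 is expected to show a step of a 1.1-fold lower number from compound 2 to compound 3 (0.05 log units; within the scatter), not beyond the scatter in either direction. Compound 3 is therefore estimated at 400 nM, within a range from 150 nM to 1200 nM.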

Compound 3, half-maximal inhibitory concentration: 90 nM
The estimate for compound 3 lay 4.4-fold (0.65 log units) above the measured number; measured number outside the range, below it.
By their numbers in this assay, from the lowest: compounds 3 and 1 (each within the scatter of the next); then compound 2.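

In this assay, 2,2-difluoroethoxy in place of trifluoromethyl on this aromatic carbon gives a 5.0-fold lower number from compound 2 to compound 3 (0.70 log units; beyond the scatter), a step beyond the scatter. This shows that the number responds to the group at this position, and that the group with one more heavy atom and one hydrogen-bond acceptor is accepted here. No measurement bears on the reason for this step.

This single pair cannot separate the contribution of the oxygen from that of the fluorines. From the compounds shown here alone, whether plain ethoxy, methoxy or an amine on this carbon would give a similar number remains open, as does whether the same change would hold in compound 1.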